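A benzyl group replaces acetoxy on compound 3

This account rests on a few compounds, and the source may have more. Where it says the series, first, only, none or still open, it means among the compounds named here.

In an ADME assay on HOS cells (Homo sapiens) for cytotoxicity, read by luminescence and ATP content, with a stated time of 48 h (a higher number here means that more compound is tolerated, a lower number that less compound is tolerated), compound 1 `COc1ccc2c(O)c(C(=O)NCc3ccc(F)cc3F)c(=O)n(O)c2n1` gives 12000 nM as its half-maximal cytotoxic concentration. Compound 2 `O=C(NCc1ccc(F)cc1F)c1c(O)c2cc(CCCCCO)cnc2n(O)c1=O` reads > 250000 nM and that is a limit of the assay. Compound 3 `CC(=O)OCCCc1cnc2c(c1)c(N)c(C(=O)NCc1ccc(F)cc1F)c(=O)n2O` reads > 250000 nM and this too is a limit. Compound 3 thus stands at the limit of > 250000 nM in this assay, at which 2 of the 3 values shown sit, with no exact number of its own. Compound 4 `Nc1c(C(=O)NCc2ccc(F)cc2F)c(=O)n(O)c2ncc(CCCCc3ccccc3)cc12` differs from it benzyl in place of acetoxy on a saturated chain carbon, three bonds along the chain from an aromatic carbon by benzyl in place of acetoxy on a saturated chain carbon, three bonds along the chain from an aromatic carbon. Compound 1 at 12000 nM shows that a measurable value can occur among these compounds, so a real move toward lower tolerance is expected. The expected step of an at least 5.0-fold lower number from compound 3 to compound 4 (0.69 log units; beyond the scatter) is downward and beyond the scatter. Compound 4 is expected at 50000 nM with an estimated range of 12000 nM to 250000 nM in this estimate.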

Compound 4, half-maximal cytotoxic concentration: 13000 nM
Beside the measured number, compound 4's estimate is 3.8-fold (0.59 log units) above it; the range from low to high includes it.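

In this assay, the group on a saturated chain carbon, three bonds along the chain from an aromatic carbon, matters: benzyl in place of acetoxy gives an at least 19-fold lower number from compound 3 to compound 4 (1.28 log units; beyond the scatter). Going by these compounds alone, this is the only step here between compounds that differ in one place, so it is the first direct reading of this position. Its true size stays unknown, because compound 3 carries a limit of the assay and not a number: the limit of > 250000 nM in this assay, at which 2 of the 4 values shown sit.

The compounds shown leave open whether the entering benzyl or the departing acetoxy drives the change. An amine at the chain end, or a shorter chain ending in phenyl, would bear on that question.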